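Halogen swap on the fused ring: fluoro to chloro

The source may report more compounds than this note shows. Statements on the series, on what has been measured and on what is new or still open speak of the compounds shown alone.

The series shares one core; compound 1 `CCn1c(=O)/c(=C2\Sc3cc(Cl)ccc3N2C)s/c1=C\c1ccccn1`, compound 2 `CCn1c(=O)/c(=C2\Sc3ccccc3N2C)s/c1=C\c1ccncc1` and compound 3 `CCn1c(=O)/c(=C2\Sc3cc(F)ccc3N2C)s/c1=C\c1ccncc1` have been measured in an ADME assay on microsomes from liver (Mus musculus) for metabolic stability, with a stated time of 30 min; on this read-out lower numbers stand for a less stable compound and higher numbers for a more stable compound. Compound 1 gives 13%, compound 2 gives 6% and compound 3 gives 13%. Compound 3 thus stands level with compound 1 at the digits shown, the two together at the top of the three numbers, while the gap to compound 2 remains within the scatter, so no ordering among the three is claimed.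

Compound 4 `CCn1c(=O)/c(=C2\Sc3cc(Cl)ccc3N2C)s/c1=C\c1ccncc1` has not been measured. It differs from compound 3 by chloro in place of fluoro on an aromatic carbon. For the measured compounds named here, the one measured step at this position is a number 7 percentage points higher from compound 2 to compound 3 (within the scatter), a change inside the scatter. Compound 1 also carries chloro on the same carbon and gives the same number as compound 3, but its structure differs elsewhere, so it offers only a loose hint that chloro here does not move this assay far.

On that basis a step of no change at the digits printed from compound 3 to compound 4 (within the scatter) is expected, that is no movement beyond the scatter. Compound 4 is estimated at 13%, within 5% to 25%.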

Compound 4, percent of the compound remaining: 39%
Estimate against measurement, compound 4: 26 percentage points below; the whole stated range lies below it.
By their numbers in this assay, from the lowest: compounds 2, 1 and 3 (each within the scatter of the next); then compound 4.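

Identity of the halogen matters at this aromatic carbon: in this assay, chloro in place of fluoro gives a number 26 percentage points higher from compound 3 to compound 4 (beyond the scatter), and chloro in place of hydrogen gives a number 33 percentage points higher from compound 2 to compound 4 (beyond the scatter), whereas fluoro in place of hydrogen gave only a number 7 percentage points higher from compound 2 to compound 3 (within the scatter). Chloro alone does not set the level, as pyridin-4-yl in place of pyridin-2-yl, with chloro held on the fused ring, gives a number 26 percentage points higher from compound 1 to compound 4 (beyond the scatter), so compound 1 goes against any reading that chloro on this carbon suffices and the loose hint drawn from it does not hold. No available data explain the size of either change.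

Going by these compounds, it remains open whether the gain from chloro also appears with pyridin-2-yl on the double-bonded chain carbon, or only with pyridin-4-yl as in compound 4. Also open, on these data alone, is whether bromo, methyl or methoxy on the same aromatic carbon would track chloro or stay with fluoro and hydrogen, and whether a longer chain in place of the ethyl group on the shared core would shift the number in this assay.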